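The source may report more compounds than this note shows. Statements on the series, on what has been measured and on what is new or still open speak of the compounds shown alone.

Compound 1 `Cc1ccc(-c2cc(/N=C3/NC(=O)CS3)cs2)cc1` and compound 2 `COc1ccc(-c2cc(/N=C3/NC(=O)CS3)cs2)cc1` share one core, while compound 3 `Cc1ccc(/C=C2\S/C(=N\c3nc(-c4ccc(Cl)cc4)cs3)NC2=O)cc1` and compound 4 `COc1ccc(/C=C2\S/C(=N\c3nc(-c4ccc(Cl)cc4)cs3)NC2=O)cc1` share a larger one; the difference between the two cores is not broken down here. All are tested in a functional assay on HT-29 cells (Homo sapiens) for cytotoxicity, read by MTT assay, with a stated time of 72 h; a lower number here means a stronger inhibitor, a higher number a weaker inhibitor. Compound 1 gives only a limit of the assay, > 50000 nM. Compound 2 likewise gives only a limit, > 50000 nM. Going by the values given here, compound 3 gives 500 nM, the one real number among the three measured compounds. Between compound 1 and compound 2 the change is methoxy in place of methyl on an aromatic carbon, and its step is a step that the two limits leave unreadable from compound 1 to compound 2, which stays unreadable because the limit of > 50000 nM in this assay, at which 2 of the 3 values shown sit, hides any movement. From compound 3 to compound 4 the change is the same one, (methoxy in place of methyl on an aromatic carbon), made on the larger core. Among the compounds with values here, since the only occurrence of this change so far gives no readable size, the expectation for compound 4 rests mainly on the value of compound 3, 500 nM, with a step of roughly a 1.2-fold higher number from compound 3 to compound 4 (0.08 log units; within the scatter) expected for so small a change. Compound 4 is therefore estimated at about 600 nM, most likely between 150 nM and 2500 nM.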

Compound 4, half-maximal inhibitory concentration: 400 nM
For compound 4 the middle estimate is 1.5-fold (0.18 log units) above the measured one; the measured number falls inside the stated range.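

On the larger core, replacing methyl with methoxy, or 4-methylphenyl with 4-methoxyphenyl when cut one bond further out, gives in this assay a 1.3-fold lower number from compound 3 to compound 4 (0.10 log units; within the scatter), so this single pair shows no readable effect of the change on that core. It does not show that the change behaves the same way on both cores, since this is the only readable occurrence and one pair cannot establish a trend. On the smaller core, the same change offers nothing to compare, as compound 1 and compound 2 each give only a limit of the assay: the limit of > 50000 nM in this assay, at which 2 of the 4 values shown sit.

The compounds shown leave open how an amine, a carboxylic acid or a longer chain such as ethoxy in place of the methoxy would read in this assay on the larger core. They also leave open whether any such replacement would move the number beyond the usual scatter, as the methoxy does not.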